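Compound 3 against the two measured EP4 binders

The source may report more compounds than this note shows. Statements on the series, on what has been measured and on what is new or still open speak of the compounds shown alone.

compound 1 `O=C(O)CCCSCCN1C(=O)CC[C@@H]1/C=C/[C@@H](O)Cc1cccc(-c2ccc3[nH]ccc3c2)c1`: 0.28 nM
compound 2 `O=C(O)CCCSCCN1C(=O)CC[C@@H]1/C=C/[C@@H](O)Cc1cccc(-c2nc3ccccc3s2)c1`: 0.36 nM

In an assay on CHO cells for displacement of a labelled ligand from prostaglandin E2 receptor EP4 subtype (Mus musculus), read by scintillation counting, with a stated time of 60 min (on this read-out lower numbers stand for stronger inhibition and higher numbers for weaker inhibition), compound 2 gives 0.36 nM, the higher of the two numbers, although a 1.3-fold higher number from compound 1 to compound 2 (0.11 log units; within the scatter) is within the scatter. Compound 3 `O=C(O)CCCSCCN1C(=O)CC[C@@H]1/C=C/[C@@H](O)Cc1cccc(OCc2ccncc2)c1` differs from compound 2 by (pyridin-4-yl)methoxy in place of 1,3-benzothiazol-2-yl on an aromatic carbon. Within the data shown here, the only measured step, a 1.3-fold higher number from compound 1 to compound 2 (0.11 log units; within the scatter), exchanged one aromatic group for another without moving the number beyond the scatter; no measured step covers a change of this sort, so it bears only loosely on the present one. A somewhat higher number is expected for compound 3, a 2.8-fold higher number from compound 2 to compound 3 (0.44 log units; beyond the scatter), with wide uncertainty. Compound 3 is estimated at 1 nM, range 0.3 nM to 5 nM.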

Compound 3, inhibition constant: 28 nM
For compound 3 the middle estimate is 28-fold (1.45 log units) below the measured one, and the stated range ends below it.
By their numbers in this assay, from the lowest: compounds 1 and 2 (each within the scatter of the next); then compound 3.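

In this assay this position does not accept every aromatic-bearing group alike: the change gives a 78-fold higher number from compound 2 to compound 3 (1.89 log units; beyond the scatter), and likewise a 100-fold higher number from compound 1 to compound 3 (2.00 log units; beyond the scatter), although 1H-indol-5-yl and 1,3-benzothiazol-2-yl had stayed within the scatter of each other. The leaving 1,3-benzothiazol-2-yl and the entering (pyridin-4-yl)methoxy have equal hydrogen-bond donor and acceptor counts, so those counts do not separate them. No evidence on hand explains the drop. Open, as far as these compounds go, is whether it follows the oxygen-containing methylene link or the pyridin-4-yl ring; a benzyloxy group and a directly bonded pyridin-4-yl would separate the two.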